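This account rests on a few compounds, and the source may have more. Where it says the series, first, only, none or still open, it means among the compounds named here.

Compound 1 `O=c1c(C2N=C(c3ccccc3)SS2)coc2ccc(Cl)cc12` carries a single chloro on its core; in a functional assay on A549 cells (Homo sapiens) for inhibition, read by sulforhodamine B assay, with a stated time of 48 h (a lower number here means a stronger inhibitor, a higher number a weaker inhibitor), compound 1 gives 71300 nM. Both measured neighbours fall within the scatter of that number: compound 2 `O=c1c(C2N=C(c3ccccc3)SS2)coc2cc(Cl)c(Cl)cc12`, which adds a second chloro, gives 95000 nM, and compound 3 `O=c1c(C(=S)Nc2ccccc2)coc2cc(Cl)c(Cl)cc12`, which has a different side chain on the same dichlorinated core, gives 71200 nM. On these numbers compound 1 is not separable from either of them. Compound 4 `O=c1c(C2N=C(c3ccccc3)SS2)coc2ccccc12` is the unmeasured analogue lacking the chloro: hydrogen in place of chloro on an aromatic carbon. Within the data shown here, the only measured step that bears on this change runs the other way, putting a chloro onto an aromatic carbon: a 1.3-fold higher number from compound 1 to compound 2 (0.12 log units; within the scatter). Since adding chlorine there moved nothing beyond the scatter, removing it in compound 4 is expected to move nothing either, a 1.0-fold lower number from compound 1 to compound 4 (0.00 log units; within the scatter). The estimate for compound 4 in this assay is therefore 71000 nM, with a range from 30000 nM to 170000 nM; a value this weak may also be returned only as a limit of the assay.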

Compound 4, half-maximal inhibitory concentration: > 100000 nM
Compound 4 ended at the assay's limit; the forecaster's own chance of this, stated with the estimate: 15%; at least 1.4-fold (0.14 log units) between middle value and limit.
By their numbers in this assay, from the lowest: compounds 3, 1 and 2 (each within the scatter of the next). At a limit, above all of these: compound 4.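

All earlier compounds carry chloro on the core, so until now the series had no reading at this position without it. In this assay compound 4 gives > 100000 nM as a limit of the assay, not a number. Hydrogen in place of chloro on this aromatic carbon gives an at least 1.4-fold higher number from compound 1 to compound 4 (0.14 log units; that floor lies within the scatter) and so fixes only a floor for the change, not its size, with the whole step resting on one limit: the limit of > 100000 nM in this assay, at which 1 of the 4 values shown sits.

As far as these compounds go, whether the true number of compound 4 lies close to that of compound 1 or far from it stays unknown, so the size of the chloro step remains unread. Also open, from the compounds shown here alone, is how bromo, a methoxy group or an amine on the same aromatic carbon would read in this assay on the shared core.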